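Direct attachment of methylpyrazole to the shared core

A few compounds are considered here, and "the series" means these few. Any claim that something is new, unique, unknown or untested is made for them only; others in the source may bear on it.

Compound 1 `COc1ccc(OC)c(Sc2ccc3nnc(-c4ccccc4)n3n2)c1` gives 1380 nM in an assay on HEK293 cells for inhibition of Leucine-rich repeat serine/threonine-protein kinase 2 (Homo sapiens), read by ELISA, with a stated time of 90 min; a higher number here means a weaker inhibitor, a lower number a stronger inhibitor. For the measured compounds named here, compound 2 `COc1ccc(OC)c(Sc2ccc3nnc(-c4cccnc4)n3n2)c1` gives 736 nM in this assay, and the step of a 1.9-fold lower number from compound 1 to compound 2 (0.27 log units; within the scatter) is the only single-point comparison measured. Compound 3 `COc1ccc(OC)c(Sc2ccc3nnc(Cc4cnn(C)c4)n3n2)c1` has "not determined" (no result reported) in this assay, so it stands nowhere on the numbers shown. Compound 4 `COc1ccc(OC)c(Sc2ccc3nnc(-c4ccn(C)n4)n3n2)c1` differs from compound 3 by 1-methyl-1H-pyrazol-3-yl in place of (1-methyl-1H-pyrazol-4-yl)methyl on an aromatic carbon. Going by the values given here, no measured step covers this change directly; the comparison of compound 1 with compound 2 exchanges one directly attached aromatic ring for another and stayed within the scatter, which is the only anchor available. Compound 4 is expected to fall near those two values, with no direction beyond the scatter assignable. The estimate for compound 4 is 1000 nM, with a range of 250 nM to 4000 nM.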

Compound 4, half-maximal inhibitory concentration: 2760 nM
Beside the measured number, compound 4's estimate is 2.8-fold (0.44 log units) below it, within the range that was stated.
By their numbers in this assay, from the lowest: compounds 2, 1 and 4 (each within the scatter of the next, the first and the last beyond it).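

For the compounds shown here, the step of a 3.8-fold higher number from compound 2 to compound 4 (0.57 log units; beyond the scatter) is the first at this position to pass the scatter in this assay, so the identity of the directly attached aromatic ring can matter here, though modestly. The step of a 2.0-fold higher number from compound 1 to compound 4 (0.30 log units; within the scatter) stays within the scatter, so 1-methyl-1H-pyrazol-3-yl and phenyl cannot be told apart. No evidence in hand explains the difference from pyridin-3-yl.

The change from compound 3 to compound 4 cannot be read. Open, from the compounds shown here alone, is how a ring bearing an amine or a carboxylic acid would behave at this position.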